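Shortening the Ester Tail from Methoxyethyl to Methyl

This account rests on a few compounds, and the source may have more. Where it says the series, first, only, none or still open, it means among the compounds named here.

In an assay on cells for inhibition of Rho-associated protein kinase 2 (Homo sapiens), read by radiometric assay and 33P incorporation, in the presence of a further agent that is not named here (a lower number here means a stronger inhibitor, a higher number a weaker inhibitor), three close relatives of one shared core have been measured. Compound 1 `CCCOC(=O)c1cccc(C(=O)Nc2cccc(-c3cc(C(=O)Nc4ccncc4F)ccc3CN)c2)c1` gives 1.8 nM, and compound 3 `CC(C)OC(=O)c1cccc(NC(=O)c2cccc(-c3cc(C(=O)Nc4ccncc4F)ccc3CN)c2)c1` gives 7 nM. Compound 2 `COCCOC(=O)c1ccc(F)c(C(=O)Nc2cccc(-c3cc(C(=O)Nc4ccncc4F)ccc3CN)c2)c1` reaches the floor of this assay at < 1 nM, which is a limit rather than a number. Compound 2 therefore stands at the low end of the three values shown, since (the limit of < 1 nM in this assay, at which 1 of the 3 values shown sits), and how far below that floor it actually lies is not known from the data.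

Compound 4 `COC(=O)c1ccc(F)c(C(=O)Nc2cccc(-c3cc(C(=O)Nc4ccncc4F)ccc3CN)c2)c1` differs from compound 2 by a single trimming of the ester tail: hydrogen in place of methoxymethyl on a saturated chain carbon bound to an oxygen next to a carbonyl group. Among the measured compounds shown here, no step between two measured compounds isolates this change, so the expectation rests on the general picture that all three measured esters sit at low nanomolar potency in this assay. The step of an at least 1.5-fold higher number from compound 2 to compound 4 (0.17 log units; that floor lies within the scatter) is expected to be small, at most a modest loss that stays close to the usual scatter. Compound 4 is accordingly estimated to give 1.5 nM, with a plausible range from 0.5 nM to 5 nM.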

Compound 4, half-maximal inhibitory concentration: < 1 nM
Compound 4 was reported as a limit; the forecaster's own chance of this, stated with the estimate: 30%; at least 1.5-fold (0.17 log units) between middle value and limit.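

In this assay compound 4, which carries methyl in place of 2-methoxyethyl on the ester, gives < 1 nM, and this is a limit and not a number. The ester tail can therefore be trimmed to methyl with the compound still at the floor of the assay, so the methoxymethyl part of the tail is not required to reach that floor, but the step from compound 2 to compound 4 cannot be read, because both compounds stand at a limit: the limit of < 1 nM in this assay, at which 2 of the 4 values shown sit. With 2-fluoro-5-(methoxycarbonyl)phenyl in place of 3-(propoxycarbonyl)phenyl on a carbonyl carbon, the data give an at least 1.8-fold lower number from compound 1 to compound 4 (0.25 log units; that floor lies within the scatter), so this change cannot be said to separate the two compounds.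

The compounds shown leave open how far past the floor compound 2 and compound 4 lie, and so whether trimming the tail changes the potency at all. Also open, from the compounds shown here alone, is whether a carboxylic acid in place of the methoxycarbonyl group, or a longer chain such as 3-methoxypropyl on the ester, would stay at the same limit.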